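Acetyl on the ring nitrogen of compound 1

This account rests on a few compounds, and the source may have more. Where it says the series, first, only, none or still open, it means among the compounds named here.

Among the compounds with values here, compound 1 `Cc1c2c(n3c1CCCNC[C@H](C)Nc1cc-3ccc1C(N)=O)CC(C)(C)CC2=O` gives 93 nM in a functional assay on HCT-116 cells (Homo sapiens) for antiproliferative activity (a lower number here means that less compound is needed, a higher number that more compound is needed for the effect), and holds the lowest of the three numbers measured so far. Compound 2 `COCCN1CC[C@H](C)Nc2cc(ccc2C(N)=O)-n2c(c(C)c3c2CC(C)(C)CC3=O)CC1=O` gives 359 nM and compound 3 `Cc1c2c(n3c1CC(=O)NCC[C@H](C)Nc1cc-3ccc1C(N)=O)CC(C)(C)CC2=O` gives 815 nM with an amide-type nitrogen in a ring. Compound 4 `CC(=O)N1CCCc2c(C)c3c(n2-c2ccc(C(N)=O)c(c2)N[C@@H](C)C1)CC(C)(C)CC3=O` comes from compound 1 through acetyl in place of hydrogen on an amine nitrogen in a ring as acetyl in place of hydrogen on an amine nitrogen in a ring. Within the data shown here, no measured step covers this change directly. The closest is a 2.3-fold higher number from compound 2 to compound 3 (0.36 log units; beyond the scatter) for hydrogen in place of 2-methoxyethyl on an amide-type nitrogen in a ring. Compound 2 at 359 nM is the nearer of that pair, so a higher number is expected in this assay with an estimated 3.2-fold higher number from compound 1 to compound 4 (0.51 log units; beyond the scatter) as the size of the move. For compound 4 the expected value is 300 nM with 100 nM to 900 nM as the estimated range.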

Compound 4, half-maximal effective concentration in the HCT-116 assay: 194 nM
Compound 4: the middle estimate sits 1.5-fold (0.19 log units) above what was measured; low and high end bracket the measured number.
By their numbers in the HCT-116 assay, from the lowest: compound 1; then compounds 4 and 2 (each within the scatter of the next); then compound 3.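

Within the data shown here, in the HCT-116 assay, the result gives the first direct reading at the amine nitrogen of compound 1: acetyl in place of hydrogen there brings a 2.1-fold higher number from compound 1 to compound 4 (0.32 log units; beyond the scatter), so this nitrogen can carry acetyl at a modest cost. In a physicochemical assay for solubility (on this read-out lower numbers stand for lower solubility and higher numbers for higher solubility), compound 1 gives > 100 ug/mL as a limit of the assay and not a number. In the physicochemical assay, compound 4 gives 69 ug/mL as a measured number. In the physicochemical assay, the same change brings an at least 1.4-fold lower number from compound 1 to compound 4 (0.16 log units; that floor lies within the scatter), which is only a floor, and the reading for compound 1 is a limit of the assay: the limit of > 100 ug/mL in the physicochemical assay, at which 1 of the 2 values shown sits.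

As far as these compounds go, it remains open how a longer acyl chain such as propanoyl, or a methanesulfonyl group, on this nitrogen would compare with acetyl in either assay.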